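The source may report more compounds than this note shows. Statements on the series, on what has been measured and on what is new or still open speak of the compounds shown alone.

In an in vitro ADME assay on microsomes from liver (Homo sapiens) for metabolic stability, tested at 0.2 uM (a lower number here means slower removal, a higher number faster removal of the compound), compound 1 `CCCCOc1cccc(OCc2[nH]c3ccccc3c(=O)c2C)c1` stands at > 1000 mL/min/kg as a limit of the assay, not a number. Going by the values given here, compound 2 `Cc1c(COc2cccc(OCC3CCOCC3)c2)[nH]c2ccccc2c1=O` gives 214 mL/min/kg in this assay as the only true number so far. Among the compounds with values here, the one measured step is an at least 4.6-fold lower number from compound 1 to compound 2 (0.66 log units; beyond the scatter) with oxan-4-yl in place of propyl on a saturated chain carbon bound to an oxygen on an aromatic ring, and it lies beyond the scatter. Compound 3 `O=c1cc(COc2cccc(OCC3CCOCC3)c2)[nH]c2ccccc12` keeps the oxan-4-yl group but carries hydrogen in place of methyl on an aromatic carbon in the shared core. The measured step lies at a different place in the structure, so it sets no size for this change. Only a small shift is therefore expected in this assay, with a 1.3-fold lower number from compound 2 to compound 3 (0.13 log units; within the scatter) as the estimated step, which stays within the scatter. The estimated clearance of compound 3 is 160 mL/min/kg with an expected range from 75 mL/min/kg to 340 mL/min/kg in repeated measurements.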

Compound 3, clearance: 78 mL/min/kg
Compound 3: middle estimate off by 2.1-fold (0.31 log units), on the high side; the range from low to high includes it.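

With hydrogen in place of methyl on this aromatic carbon, this assay shows a 2.7-fold lower number from compound 2 to compound 3 (0.44 log units; beyond the scatter) and so gives the first sign that this position of the shared core affects clearance. The earlier step changed only the chain on the oxygen, leaving this position untouched. How the sizes of the two steps compare cannot be read, because compound 1 gives only a limit of the assay: the limit of > 1000 mL/min/kg in this assay, at which 1 of the 3 values shown sits.

On these data alone, this change is seen in a single pair, with the oxan-4-yl chain in place, so whether it gives a similar step with other chains remains open. Also open are the effect of an ethyl, a chlorine or a methoxy at this carbon and the cause of the shift, which these values do not reveal.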